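Methyl on the phenoxy ring: lipophilicity notes

The source may hold more compounds than are shown below. What is called first, only, known or untested is meant among the compounds shown, and "the series" means these compounds.

Measured in a physicochemical assay for lipophilicity, in phosphate buffer, measured as octanol-water partition; on this read-out lower numbers stand for lower lipophilicity and higher numbers for higher lipophilicity:
compound 1 `CCCc1nc2ccccc2c(=O)n1/N=C/c1ccc(Oc2ccc(Cl)cc2)cc1` gives 5.78
compound 2 `CCCc1nc2ccccc2c(=O)n1/N=C/c1ccc(Oc2ccc(Cl)c(C)c2)cc1` gives 6.02
compound 3 `O=c1c2ccccc2nc(-c2ccccc2)n1/N=C/c1ccc(Oc2ccccc2)cc1` gives 6.13

Compound 2 differs from compound 1 by methyl in place of hydrogen on an aromatic carbon; the step in this assay is a number 0.24 log units higher from compound 1 to compound 2 (within the scatter). Compound 4 `Cc1ccc(Oc2ccc(/C=N/n3c(-c4ccccc4)nc4ccccc4c3=O)cc2)cc1` is not yet measured; it differs from compound 3 by methyl in place of hydrogen on an aromatic carbon. This is the same kind of change, but the surroundings differ: in compound 2 the methyl sits ortho to a chloro group and meta to a large group, in compound 4 it sits para to a large group. The difference between the two cores is not broken down here. Compound 3 in this assay stands at 6.13, and compound 4 is expected to come out at 6.4, between 6.1 and 6.7. That estimate means a step of a number 0.27 log units higher from compound 3 to compound 4 (within the scatter), resting on the earlier methyl step a number 0.24 log units higher from compound 1 to compound 2 (within the scatter).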

Compound 4, partition coefficient: 6.29
Compound 4: middle estimate off by 0.11 log units, on the high side; the measured number falls inside the stated range.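

In this assay the methyl change reads a number 0.16 log units higher from compound 3 to compound 4 (within the scatter) on one core and a number 0.24 log units higher from compound 1 to compound 2 (within the scatter) on the other. Each step lies within the usual scatter, so the two cores agree only in that neither shows a step clear of repeat measurement, and these two pairs do not establish a real methyl effect that carries from one core to another. Nothing available bears on what lies behind either step.

The compounds shown leave open whether an amine or a carboxylic acid in place of the methyl would give a step beyond the scatter. They also leave open whether a longer chain at that place would read alike on both cores.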